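The source may hold more compounds than are shown below. What is called first, only, known or untested is meant among the compounds shown, and "the series" means these compounds.

Compound 1, `CS/C(=N\C#N)N(C)Cc1ccc(Cl)nc1`: 1.4
Compound 2, `CN(Cc1ccc(Cl)nc1)/C(N)=N/C#N`: 0.71
Compound 3, `CN/C(=N\C#N)N(C)Cc1ccc(Cl)nc1`: 0.78

All three numbers come from a physicochemical assay for lipophilicity, using the shake flask method, measured as octanol-water partition, at 23 degrees C; a higher number here means a more lipophilic compound, a lower number a more polar compound. Among them compound 3 stands second highest: the step of a number 0.07 log units higher from compound 2 to compound 3 (within the scatter) lies within the scatter, while the step of a number 0.62 log units lower from compound 1 to compound 3 (beyond the scatter) lies beyond it. Compound 4, `CCN/C(=N\C#N)N(C)Cc1ccc(Cl)nc1`, differs from compound 3 by methyl in place of hydrogen on a saturated chain carbon bound to an amine nitrogen. Among the compounds with values here, no measured step makes this same change. The nearest comparison is the step of a number 0.07 log units higher from compound 2 to compound 3 (within the scatter), which also puts a methyl in place of a hydrogen on the amine side of the shared core and stayed within the scatter. The two larger steps, a number 0.69 log units lower from compound 1 to compound 2 (beyond the scatter) and a number 0.62 log units lower from compound 1 to compound 3 (beyond the scatter), concern the exchange of methylsulfanyl for an amino or methylamino group and do not speak to a methyl-to-ethyl extension. The expected outcome is therefore a small rise in this assay, a number 0.32 log units higher from compound 3 to compound 4 (beyond the scatter), at or just beyond the scatter. On that basis compound 4 is estimated at 1.1, within a range from 0.8 to 1.5.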

Compound 4, partition coefficient: 1.02
The estimate for compound 4 lay 0.08 log units above the measured number; the range from low to high includes it.
By their numbers in this assay, from the lowest: compounds 2, 3 and 4 (each within the scatter of the next, the first and the last beyond it); then compound 1.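

In this assay, methyl to ethyl on a saturated chain carbon bound to an amine nitrogen gives a number 0.24 log units higher from compound 3 to compound 4 (within the scatter), so this single added methyl does not separate the two compounds. With ethyl in place of hydrogen on the amine nitrogen, the result is a number 0.31 log units higher from compound 2 to compound 4 (beyond the scatter), the first change at this amine nitrogen among those shown to pass the scatter, whereas methyl there had not. Even with ethylamino in place of methylsulfanyl, the step is a number 0.38 log units lower from compound 1 to compound 4 (beyond the scatter), so compound 4 remains apart from compound 1 beyond the scatter.

No evidence is available on what lies behind these steps. From the compounds shown here alone, it remains open whether a longer chain such as propyl or butyl in place of ethyl would stand beyond the scatter from compound 3 in this assay, and how a chain ending in a hydroxyl group would read there.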